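The compounds below may be only part of what the source reports. "The series", "measured", "known", "first", "only" and "open" are said of these compounds alone.

Compound 1 `COc1ccc(OC)c(-c2cc(-c3ccccc3)nn2-c2ccc(S(=O)(=O)NC(C)=O)cc2)c1`: 13300 nM
Compound 2 `COc1ccc(OC)c(-c2cc(-c3ccc(Cl)cc3)nn2-c2ccc(S(=O)(=O)NC(C)=O)cc2)c1`: 23400 nM
Compound 3 `NS(=O)(=O)c1ccc(-n2nc(-c3ccccc3)cc2-c2cc(O)ccc2O)cc1`: 81300 nM

These numbers come from a functional assay on cells (Cancer cell lines, Homo sapiens) for cytotoxicity, read by sulforhodamine B assay, with a stated time of 48 h; a lower number here means a stronger inhibitor of growth, a higher number a weaker inhibitor of growth. Compound 1 and compound 2 share one core and differ only by chloro in place of hydrogen on an aromatic carbon; that change gave a 1.8-fold higher number from compound 1 to compound 2 (0.25 log units; within the scatter). Compound 3 is built on another core, and the difference between the two cores is not broken down here. In this assay compound 3 gives the highest of the three numbers, beyond the scatter from both compound 1 and compound 2.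

Compound 4 `NS(=O)(=O)c1ccc(-n2nc(-c3ccc(Cl)cc3)cc2-c2cc(O)ccc2O)cc1` has not yet been measured in this assay. It differs from compound 3 by chloro in place of hydrogen on an aromatic carbon, the same change as that between compound 1 and compound 2, in the same place. Because that earlier step was a 1.8-fold higher number from compound 1 to compound 2 (0.25 log units; within the scatter), for compound 4 a step of similar size is expected, a 1.5-fold higher number from compound 3 to compound 4 (0.17 log units; within the scatter). The estimate for compound 4 is 120000 nM, between 50000 nM and 300000 nM.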

Compound 4, concentration for 50% growth inhibition: 14700 nM
Compound 4: the middle estimate sits 8.2-fold (0.91 log units) above what was measured; the whole stated range lies above it.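

In this assay the change from phenyl to 4-chlorophenyl gave a 5.5-fold lower number from compound 3 to compound 4 (0.74 log units; beyond the scatter) on this core, so the step seen on the core of compound 1 did not carry over in size or direction. The two steps differ clearly: the same change on two cores in this assay, a 1.8-fold higher number (0.25 log units; within the scatter) from compound 1 to compound 2 and a 5.5-fold lower number (0.74 log units; beyond the scatter) from compound 3 to compound 4, 9.7-fold (0.99 log units) apart, beyond the scatter of two such steps. This shows that, for these two cores, a step read on one is a poor guide to the other, but with one pair per core it does not show why the steps differ or which difference between the cores matters.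

The compounds shown leave open whether another group in the same place, such as an amine or a carboxylic acid, would also behave differently on the two cores.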